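Swapping a trifluoromethyl ketone for a methoxypyridine

The compounds below may be only part of what the source reports. "The series", "measured", "known", "first", "only" and "open" are said of these compounds alone.

Compound 1 `O=C(CCCCCCc1ccccc1)c1ncc(-c2cccs2)s1`: > 10000 nM
Compound 2 `O=C(CCCCCCc1ccccc1)c1ncc(C(=O)C(F)(F)F)o1`: 1820 nM

Of the compounds shown here, two have been tested in an assay on HEK-293T cells for inhibition of diacylglycerol lipase-alpha (Homo sapiens), read by colorimetric assay; a higher number here means a weaker inhibitor, a lower number a stronger inhibitor. Compound 1 reaches only > 10000 nM, which is a limit of the assay and not a number, (the limit of > 10000 nM in this assay, at which 1 of the 2 values shown sits). Among the measured compounds shown here, compound 2 gives 1820 nM, the only real number in this small set, so it stands alone as the one measured inhibitor.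

Compound 3 `COc1ccc(-c2cnc(C(=O)CCCCCCc3ccccc3)o2)nc1` differs from compound 2 in a single place: 5-methoxypyridin-2-yl in place of (trifluoromethyl)carbonyl on an aromatic carbon. For the measured compounds named here, no measured step between two compounds is available to gauge such a change. Compound 1, which also carries an aromatic ring on its core, sits at the limit > 10000 nM, which points toward weaker inhibition for compound 3. A step toward weaker inhibition, beyond the usual scatter, is therefore expected in this assay, as a 4.4-fold higher number from compound 2 to compound 3 (0.64 log units; beyond the scatter). Compound 3 is estimated at 8000 nM, within a range of 2500 nM to 30000 nM.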

Compound 3, half-maximal inhibitory concentration: > 10000 nM
Compound 3 ended at the assay's limit; the forecaster's own chance of this, stated with the estimate: 45%; middle value at least 1.2-fold (0.09 log units) from the limit.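

Among the compounds shown here, replacing (trifluoromethyl)carbonyl with 5-methoxypyridin-2-yl on the aromatic carbon next to the ring oxygen gives, in this assay, an at least 5.4-fold higher number from compound 2 to compound 3 (0.73 log units; beyond the scatter), the first measured step at this position. On these data alone, compound 3 gives > 10000 nM, which is a limit of the assay and not a number, so the true size of the step remains unknown. This one aromatic ring does not retain the inhibition seen with (trifluoromethyl)carbonyl at this position, and the set still holds only one real number: the limit of > 10000 nM in this assay, at which 2 of the 3 values shown sit.

The compounds shown leave open whether the loss follows from the pyridine ring itself or from its methoxy group, which a plain phenyl ring could help to separate. They also leave open whether a methyl ketone or a methyl ester at this position would stay closer to compound 2.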